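This account rests on a few compounds, and the source may have more. Where it says the series, first, only, none or still open, it means among the compounds named here.

In an ADME assay on microsomes from liver (Rattus norvegicus) for metabolic stability, with a stated time of 10 min (on this read-out lower numbers stand for a less stable compound and higher numbers for a more stable compound), compound 1 (`COc1ccc(Nc2nc(Cl)cn([C@H](C)C3CC3)c2=O)c(C)n1`) stands at 89% and compound 2 (`Cc1cc(C)c(Nc2nc(Cl)cn([C@H](C)C3CC3)c2=O)c(C)n1`) at 87% while compound 3 (`COc1nc(C)c(Nc2nc(Cl)cn([C@H](C)C3CC3)c2=O)cc1C`) reads 77% on the same scale. Compound 3 lies within the scatter of compound 2 but not of compound 1. Compound 4 (`Cc1cc(Nc2nc(Cl)cn([C@H](C)C3CC3)c2=O)c(C)nc1N(C)C`) has dimethylamino in place of methoxy on an aromatic carbon next to the ring nitrogen. For the measured compounds named here, the only measured step is a number 12 percentage points lower from compound 1 to compound 3 (beyond the scatter) for methyl in place of hydrogen on an aromatic carbon. Going by the values given here, it is a different change, so it offers only a size, and no measured step covers this swap. The expected step is a number 9 percentage points lower from compound 3 to compound 4 (within the scatter) in this assay as a modest downward move, though the direction is poorly supported. The estimate for compound 4 is 68% with an expected range from 50% to 84% in this series.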

Compound 4, percent of the compound remaining: 54%
Compound 4: middle estimate off by 14 percentage points, on the high side, and the stated range covers the measured number.
By their numbers in this assay, from the lowest: compound 4; then compounds 3, 2 and 1 (each within the scatter of the next, the first and the last beyond it).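

In this assay, the carbon next to the ring nitrogen proves sensitive to the group it carries: dimethylamino in place of methoxy gives a number 23 percentage points lower from compound 3 to compound 4 (beyond the scatter). The earlier compounds shown here showed no swap at this carbon, only a methyl change elsewhere on the ring. Nothing available accounts for the size of this step. Open, from the compounds shown here alone, is how a smaller amine such as methylamino, or a cyclic amine such as morpholine, would read at this carbon. Also open, going by these compounds, is whether the same swap gives a similar step without the added ring methyl of compound 3.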